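Inverting the Stereocentres of Compound 2

The source may hold more compounds than are shown below. What is called first, only, known or untested is meant among the compounds shown, and "the series" means these compounds.

Measured so far in a functional assay on HeLa cells (Homo sapiens) for inhibition, read by CCK-8 assay, with a stated time of 48 h; a lower number here means a stronger inhibitor, a higher number a weaker inhibitor:
Compound 1 `COc1ccc(Oc2ccc(C(C)C)cc2-c2ccsc2S(=O)(=O)NCCNC(=S)Nc2ccc([N+](=O)[O-])cc2)cc1OC` gives 11900 nM
Compound 2 `O=C(NCCNS(=O)(=O)c1ccc(-c2ccccc2O[C@H]2CC[C@@H](O)CC2)s1)Nc1ccc([N+](=O)[O-])cc1` gives > 20000 nM (a limit)

In this assay compound 2 stands only at a limit (> 20000 nM) and has no number of its own. Going by the values given here, compound 1 is the one compound here with a measured number (11900 nM).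

Compound 3 `O=C(NCCNS(=O)(=O)c1ccc(-c2ccccc2O[C@H]2CC[C@H](O)CC2)s1)Nc1ccc([N+](=O)[O-])cc1` keeps the same atoms and bonds as compound 2, and the whole change lies in the drawn configuration at the saturated ring carbons: the two compounds have the same atoms and bonds and differ only in configuration as drawn: 2 of 2 stereo elements differ (all stereocentres are inverted: mirror images); a stereocentre at a saturated ring carbon is drawn s in compound 2 and r in compound 3; a stereocentre at a saturated ring carbon is drawn s in compound 2 and r in compound 3. Among the compounds with values here, no measured pair here shows what such an inversion does in this assay, so no shift beyond the usual scatter is expected in either direction. The expected size is small, with an estimated step (a step that the limit leaves unreadable from compound 2 to compound 3) that stays within that scatter. The estimate for compound 3 is 24000 nM, with an expected range from 11000 nM to 50000 nM.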

Compound 3, half-maximal inhibitory concentration: 10500 nM
Compound 3: the middle estimate sits 2.3-fold (0.36 log units) above what was measured, and the stated range ends above it.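

In this assay the inversion at the saturated ring carbons gives an at least 1.9-fold lower number from compound 2 to compound 3 (0.27 log units; that floor lies within the scatter). This is the first pair shown in which configuration stands alone as the change, so any difference between the two can be traced to that single point: the fact that compounds 2 and 3 differ only in the configuration as drawn. Compound 2 stands at a limit, so only a floor for the step can be read, and that floor lies within the usual scatter: the limit of > 20000 nM in this assay, at which 1 of the 3 values shown sits.

The compounds shown leave open whether one stereocentre or the other carries the step, as both are inverted together. They also leave open whether the same inversion would matter if an amine or a carboxylic acid took the place of the hydroxyl group on the saturated ring.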